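The source may hold more compounds than are shown below. What is called first, only, known or untested is meant among the compounds shown, and "the series" means these compounds.

In a functional assay on DU-145 cells (Homo sapiens) for inhibition, read by MTT assay, with a stated time of 24 h (a lower number here means a stronger inhibitor, a higher number a weaker inhibitor), the evidence so far is thin. Compound 1 `CCOC1c2cc(OCc3cc(C)cc(C)c3)c(OCc3cc(C)cc(C)c3)cc2CCN1C(=O)OC(C)(C)C` gives > 20000 nM, which is a limit of the assay and not a number. For compound 2 `CCC[C@@H]1C[C@@H](O)/C=C\C(CC)[C@H]2c3cc(OCc4ccccc4)c(OCc4ccccc4)cc3CCN12` the entry reads "not determined" (no result reported), so it adds nothing to the scale. Going by the values given here, what the data offer is therefore (the limit of > 20000 nM in this assay, at which 1 of the 2 values shown sits), and no pair of measured compounds gives a step to calibrate against.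

Compound 3 `C/C=C/C(=O)CC1c2cc(OCc3cc(C)cc(C)c3)c(OCc3cc(C)cc(C)c3)cc2CCN1C(=O)OC(C)(C)C` keeps the core of compound 1 and differs in one place: on a saturated ring carbon, next to the ring nitrogen, ((prop-1-en-1-yl)carbonyl)methyl stands in place of ethoxy (((prop-1-en-1-yl)carbonyl)methyl in place of ethoxy on a saturated ring carbon).

Since compound 1 is known only through the limit > 20000 nM, the size of any change in this assay cannot be pinned down, and only a modest move toward stronger inhibition, or none beyond the scatter, is expected. The expected step is an at least 1.3-fold lower number from compound 1 to compound 3 (0.12 log units; that floor lies within the scatter). For compound 3 the estimated value is 15000 nM, with an expected range from 4000 nM to 40000 nM.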

Compound 3, half-maximal inhibitory concentration: > 20000 nM
Compound 3: no number, only a limit; the forecaster's own chance of this, stated with the estimate: 50%; middle value at least 1.3-fold (0.12 log units) away from the limit.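

In this assay compound 3 gives > 20000 nM, which is a limit of the assay and not a number. Going by these compounds alone, compound 1 also stands at a limit, so no step between compound 1 and compound 3 can be read. The compounds shown leave open whether ((prop-1-en-1-yl)carbonyl)methyl in place of ethoxy changes inhibition at all, and the data end at a single boundary: the limit of > 20000 nM in this assay, at which 2 of the 3 values shown sit.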